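The source may report more compounds than this note shows. Statements on the series, on what has been measured and on what is new or still open speak of the compounds shown alone.

Going by the values given here, in a functional assay on PC-3M cells (Homo sapiens) for inhibition, read by sulforhodamine B assay (on this read-out higher numbers stand for weaker inhibition and lower numbers for stronger inhibition), compound 2 (`NCC1CCN(c2ncnc3[nH]ccc23)CC1`) gives 32000 nM, the highest of the three numbers so far. Compound 1 (`NCC1(Cc2ccc(Cl)cc2)CCN(c2ncnc3[nH]ccc23)CC1`) gives 15000 nM, and compound 3 (`NC(c1ccc(Cl)cc1)C1CCN(c2ccnc3[nH]ccc23)CC1`) gives 5300 nM. Compound 4 (`NC(c1ccccc1)C1CCN(c2ncnc3[nH]ccc23)CC1`) carries phenyl in place of hydrogen on a saturated chain carbon bound to an amine nitrogen and a saturated ring carbon. Among the compounds with values here, the only measured step, a 2.1-fold higher number from compound 1 to compound 2 (0.33 log units; beyond the scatter), replaces 4-chlorobenzyl with hydrogen on a saturated ring carbon, so it bears on this change only indirectly. Compound 3 differs from compound 4 in more than one place and offers loose support. A modest step to a lower number is therefore expected in this assay, estimated as a 2.5-fold lower number from compound 2 to compound 4 (0.39 log units; beyond the scatter). For compound 4 the estimated value is 13000 nM, within an expected range of 5500 nM to 30000 nM.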

Compound 4, half-maximal inhibitory concentration: 38000 nM
For compound 4 the middle estimate is 2.9-fold (0.47 log units) below the measured one; measured number outside the range, above it.
By their numbers in this assay, from the lowest: compound 3; then compound 1; then compounds 2 and 4 (each within the scatter of the next).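

The exchange of hydrogen for phenyl on a saturated chain carbon bound to an amine nitrogen and a saturated ring carbon gives a 1.2-fold higher number from compound 2 to compound 4 (0.07 log units; within the scatter) in this assay and so leaves the number unchanged within the scatter. This position therefore accepts an added aromatic ring with no measurable gain or loss in inhibition, at least for this one pair of compounds. Nothing available explains this result. The compounds shown leave open whether methyl or a pyridine ring on this same carbon would shift the number.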